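Shifting a hydroxy group on a weakly active pair

The compounds below may be only part of what the source reports. "The series", "measured", "known", "first", "only" and "open" are said of these compounds alone.

Compound 1 `Fc1cccc(-c2nc(Nc3ccccc3)c3cc(F)ccc3n2)c1`: in a functional assay on MDA-MB-231 cells (Homo sapiens) for cytotoxicity, read by MTT assay, with a stated time of 48 h (on this read-out higher numbers stand for weaker inhibition and lower numbers for stronger inhibition), compound 1 gives 47800 nM.
Compound 2 `Oc1cccc(Nc2nc(-c3cccc(F)c3)nc3ccc(F)cc23)c1`: in this assay compound 2 reaches only a limit of the assay, > 50000 nM.

Compound 2 thus sits at the assay limit (the limit of > 50000 nM in this assay, at which 1 of the 2 values shown sits). Within the data shown here, the only measured step, an at least 1.0-fold higher number from compound 1 to compound 2 (0.01 log units; that floor lies within the scatter), lies within the scatter. Compound 3 `Oc1ccccc1Nc1nc(-c2cccc(F)c2)nc2ccc(F)cc12` differs from compound 2 by 2-hydroxyphenyl in place of 3-hydroxyphenyl on a nitrogen on an aromatic ring. Among the measured compounds shown here, no measured step moves a hydroxy group from one position to another, so this change has no direct precedent among the values shown. Compound 3 is therefore expected to remain near the limit, with an estimated step that the limit leaves unreadable from compound 2 to compound 3 and an expected value of 60000 nM, between 25000 nM and 150000 nM.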

Compound 3, half-maximal inhibitory concentration: > 50000 nM
Compound 3 ended at the assay's limit; the forecaster's own chance of this, stated with the estimate: 60%; the middle value lies beyond the limit too.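

With 2-hydroxyphenyl in place of 3-hydroxyphenyl on the nitrogen, the step between compound 2 and compound 3 cannot be read, so this assay cannot rank these two hydroxy placements: the limit of > 50000 nM in this assay, at which 2 of the 3 values shown sit.

The second placement repeats the picture of the first: the record shows an at least 1.0-fold higher number from compound 1 to compound 3 (0.01 log units; that floor lies within the scatter) and so neither placement gives a stronger result than the ring without hydroxy.

From the compounds shown here alone, whether an amine or a carboxylic acid on this phenyl ring would bring a value down from the limit stays open.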